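Removing Chloro from an Isatin-Derived Core: Cytotoxicity Outlook

The source may hold more compounds than are shown below. What is called first, only, known or untested is meant among the compounds shown, and "the series" means these compounds.

Measured compounds:
- compound 1, `O=C1C(=O)N(CN(c2ccccc2)c2ccccc2)c2cccc(Cl)c21`: 96800 nM
- compound 2, `O=C1C(=O)N(CN(c2ccccc2)c2ccccc2)c2ccccc21`: 33700 nM
- compound 3, `Cc1ccc2nc(/N=C3\C(=O)N(CN(c4ccccc4)c4ccccc4)c4cccc(Cl)c43)sc2c1`: 67800 nM

In an ADME assay on 184B5 cells (Homo sapiens) for cytotoxicity, read by sulforhodamine B assay, with a stated time of 48 h (a higher number here means a weaker inhibitor of growth, a lower number a stronger inhibitor of growth), compound 1 gives 96800 nM and compound 2 gives 33700 nM. The change between them, (hydrogen in place of chloro on an aromatic carbon), produced a 2.9-fold lower number from compound 1 to compound 2 (0.46 log units; beyond the scatter). Compound 3, with `Cc1ccc2nc(/N=C3\C(=O)N(CN(c4ccccc4)c4ccccc4)c4cccc(Cl)c43)sc2c1`, gives 67800 nM in this assay; the difference between its core and the core of compound 1 is not broken down here. Compound 4, `Cc1ccc2nc(/N=C3\C(=O)N(CN(c4ccccc4)c4ccccc4)c4ccccc43)sc2c1`, is not yet measured. It differs from compound 3 by hydrogen in place of chloro on an aromatic carbon, the same change seen from compound 1 to compound 2.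

Because a 2.9-fold lower number from compound 1 to compound 2 (0.46 log units; beyond the scatter) was modest, compound 4 is expected to show a 2.7-fold lower number from compound 3 to compound 4 (0.43 log units; beyond the scatter) in this assay. On that basis compound 4 is estimated at 25000 nM, with a range from 10000 nM to 60000 nM expected.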

Compound 4, concentration for 50% growth inhibition: 27200 nM
Compound 4: middle estimate off by 1.1-fold (0.04 log units), on the low side; measured number inside the range.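

In this assay, hydrogen in place of chloro on an aromatic carbon gave a 2.5-fold lower number from compound 3 to compound 4 (0.40 log units; beyond the scatter), so the change carried over to the second core at much the same size. The two steps agree: the same change on two cores in this assay, a 2.9-fold lower number (0.46 log units; beyond the scatter) from compound 1 to compound 2 and a 2.5-fold lower number (0.40 log units; beyond the scatter) from compound 3 to compound 4, 1.2-fold (0.06 log units) apart, within the scatter of two such steps. Within the data shown here, this rests on only two pairs in a single cell assay, and it does not show that the change would behave the same way on any other core or in any other assay.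

The compounds shown leave open what other groups on that aromatic carbon, such as fluoro, methoxy or an amine, would do on either core. They also leave open whether the step would hold if a carboxylic acid replaced the methyl group of compound 3 and compound 4.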